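This account rests on a few compounds, and the source may have more. Where it says the series, first, only, none or still open, it means among the compounds named here.

Measured compounds:
Compound 1 `COc1ccc(C(=O)/C=C/c2cc(-c3cc(OC)c(OC)c(OC)c3)n[nH]2)cc1OC` — 3340 nM
Compound 2 `COc1ccc(C(=O)/C=C/c2cc(-c3cc(OC)c(OC)c(OC)c3)n[nH]2)cc1` — 4420 nM

Both compounds share a core and were tested in a functional assay on SK-MEL-28 cells (Homo sapiens) for inhibition, read by sulforhodamine B assay, with a stated time of 48 h; on this read-out lower numbers stand for stronger inhibition of growth and higher numbers for weaker inhibition of growth. Compound 2 gives the highest of the two numbers, with compound 1 nearest; the step of a 1.3-fold higher number from compound 1 to compound 2 (0.12 log units; within the scatter) comes from swapping hydrogen in place of methoxy on an aromatic carbon.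

Compound 3 `COc1cc(-c2cc(/C=C/C(=O)c3ccc(F)c(F)c3)[nH]n2)cc(OC)c1OC` is not yet measured. It differs from compound 2 in this way: 3,4-difluorophenyl in place of 4-methoxyphenyl on a carbonyl carbon. Among the measured compounds shown here, no measured step touches this part of the molecule, so the only guide is that the one measured change on the aryl ketone side, a 1.3-fold higher number from compound 1 to compound 2 (0.12 log units; within the scatter), stayed within the scatter. On that basis the step of a 1.0-fold higher number from compound 2 to compound 3 (0.01 log units; within the scatter) is expected to be small, with no clear direction. For compound 3 the expected value in this assay is 4500 nM, with a range from 1500 nM to 13000 nM.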

Compound 3, concentration for total growth inhibition: 28200 nM
Compound 3: the middle estimate sits 6.3-fold (0.80 log units) below what was measured, outside the stated range (above it).
By their numbers in this assay, from the lowest: compounds 1 and 2 (each within the scatter of the next); then compound 3.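

Removing one methoxy from the ring on the carbonyl carbon changed little, but changing what that ring carries can matter: in this assay, 3,4-difluorophenyl in place of 4-methoxyphenyl gives a 6.4-fold higher number from compound 2 to compound 3 (0.80 log units; beyond the scatter) and weaker inhibition of growth. Set against 3,4-dimethoxyphenyl, the same ring gives an 8.4-fold higher number from compound 1 to compound 3 (0.93 log units; beyond the scatter) and again weaker inhibition, so of the three rings tested here, only the difluoro ring stands apart from the other two. No measurement is available that explains this step.

Going by these compounds, it remains open whether the change follows from having fluorine on the ring or simply from having no methoxy there. A plain phenyl ring, or a ring carrying a single fluorine or an amine, could show whether such compounds sit with compound 2 or with compound 3.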